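Demethylation of an Aryl Methyl Ether in Two Urea Series

The source may report more compounds than this note shows. Statements on the series, on what has been measured and on what is new or still open speak of the compounds shown alone.

Compound 1 `COc1cc(-c2nn(-c3cccc(NC(=O)Nc4cc(C(F)(F)F)cc(C(F)(F)F)c4)c3)cc2-c2ccncc2)ccc1Cl`: 1120 nM
Compound 2 `O=C(Nc1cccc(-n2cc(-c3ccncc3)c(-c3ccc(Cl)c(O)c3)n2)c1)Nc1cc(C(F)(F)F)cc(C(F)(F)F)c1`: 849 nM
Compound 3 `COc1cc(-c2nn(-c3cccc(NC(=O)Nc4ccc(Cl)c(C(F)(F)F)c4)c3)cc2-c2ccncc2)ccc1Cl`: 1290 nM

Of the compounds shown here, three have been measured in a functional assay on OVCAR-4 cells (Homo sapiens) for inhibition, read by sulforhodamine B assay, with a stated time of 48 h; on this read-out higher numbers stand for weaker inhibition of growth and lower numbers for stronger inhibition of growth. Compound 1 `COc1cc(-c2nn(-c3cccc(NC(=O)Nc4cc(C(F)(F)F)cc(C(F)(F)F)c4)c3)cc2-c2ccncc2)ccc1Cl` gives 1120 nM, and compound 2 `O=C(Nc1cccc(-n2cc(-c3ccncc3)c(-c3ccc(Cl)c(O)c3)n2)c1)Nc1cc(C(F)(F)F)cc(C(F)(F)F)c1` gives 849 nM. The change between them, (hydrogen in place of methyl on an oxygen on an aromatic ring), made a step of a 1.3-fold lower number from compound 1 to compound 2 (0.12 log units; within the scatter). Compound 3 `COc1cc(-c2nn(-c3cccc(NC(=O)Nc4ccc(Cl)c(C(F)(F)F)c4)c3)cc2-c2ccncc2)ccc1Cl` gives 1290 nM; its values and those of compound 1 and compound 2 all lie within the scatter of one another, so no order among them can be read. The difference between the core of compound 1 and the core of compound 3 is not broken down here.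

Compound 4 `O=C(Nc1cccc(-n2cc(-c3ccncc3)c(-c3ccc(Cl)c(O)c3)n2)c1)Nc1ccc(Cl)c(C(F)(F)F)c1` has not yet been measured in this assay. It stands to compound 3 as compound 2 stands to compound 1: the change is hydrogen in place of methyl on an oxygen on an aromatic ring, the same change on the same kind of place. Because the earlier step was a 1.3-fold lower number from compound 1 to compound 2 (0.12 log units; within the scatter), a step of similar, small size is expected from compound 3 to compound 4, namely a 1.3-fold lower number from compound 3 to compound 4 (0.11 log units; within the scatter). Compound 4 is therefore estimated at 1000 nM, with a range of 500 nM to 2100 nM expected.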

Compound 4, concentration for 50% growth inhibition: 1200 nM
Beside the measured number, compound 4's estimate is 1.2-fold (0.08 log units) below it, and the stated range covers the measured number.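

In this assay, the move from methoxy to hydroxy gave a 1.1-fold lower number from compound 3 to compound 4 (0.03 log units; within the scatter) on the core of compound 3, and this step lies within the scatter. Set beside the earlier step on the core of compound 1, the change carried over from one core to the other with no difference that can be read: the same change on two cores in this assay, a 1.3-fold lower number (0.12 log units; within the scatter) from compound 1 to compound 2 and a 1.1-fold lower number (0.03 log units; within the scatter) from compound 3 to compound 4, 1.2-fold (0.09 log units) apart, within the scatter of two such steps. For the compounds shown here, both steps are small, so this agreement shows only that the change left the read-out within the scatter on these two cores; it does not show that the step would stay this small on a further core, and it gives no reason for the result.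

The compounds shown leave open what an amine, a carboxylic acid or a longer chain such as ethoxy would do in place of the hydroxy group on the 4-chloro-3-hydroxyphenyl group. Also open, on these data alone, is whether a nitrile in place of its chloro group would shift the read-out beyond the scatter.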